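Working notes: the step from compound 1 to compound 4

The source may report more compounds than this note shows. Statements on the series, on what has been measured and on what is new or still open speak of the compounds shown alone.

In a functional assay on A-431 cells (Homo sapiens) for antiproliferative activity, read by MTT assay, with a stated time of 72 h (a higher number here means a weaker inhibitor, a lower number a stronger inhibitor), compound 1 (`C=CC(=O)Nc1cc2c(Nc3ccc(OCc4cccc(F)c4)c(Cl)c3)ncnc2cc1OCc1cn(CCCC(=O)NO)nn1`) gives 19900 nM and lies within the scatter of compound 2 (`C=CC(=O)Nc1cc2c(Nc3cccc(Cl)c3F)ncnc2cc1OCc1cn(CCCCC(=O)NO)nn1`) at 15600 nM in the same read-out. Compound 3 (`CN(C)C/C=C/C(=O)Nc1cc2ncnc(Nc3ccc(F)c(Cl)c3)c2cc1O[C@@H]1CCOC1`) stands apart at 590 nM with a number lower than compound 1 by a margin beyond the scatter, so compound 1 sits at the weak end of this small set.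

Compound 4 (`C=CC(=O)Nc1cc2c(Nc3ccc(F)c(Cl)c3)ncnc2cc1OCc1cn(CCCC(=O)NO)nn1`) carries fluoro in place of (3-fluorobenzyl)oxy on an aromatic carbon, ortho to a chloro group and para to a large group (fluoro in place of (3-fluorobenzyl)oxy on an aromatic carbon). Among the compounds with values here, no measured pair isolates this change. Compound 2 also lacks the (3-fluorobenzyl)oxy group and still gives 15600 nM in this assay so no large gain is expected from its loss alone. Compound 4 shares the fluoro and chloro groups with compound 3, which gives 590 nM but differs elsewhere, and this leaves room for a modest fall. The estimated step of a 2.2-fold lower number from compound 1 to compound 4 (0.34 log units; beyond the scatter) is expected to point to a lower number and to be small. The expected value for compound 4 is 9000 nM with an estimated range from 2500 nM to 25000 nM in this read-out.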

Compound 4, half-maximal inhibitory concentration: 20700 nM
The estimate for compound 4 lay 2.3-fold (0.36 log units) below the measured number, within the range that was stated.
By their numbers in this assay, from the lowest: compound 3; then compounds 2, 1 and 4 (each within the scatter of the next).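

In this assay, within the data shown here, the exchange of (3-fluorobenzyl)oxy for fluoro gives a 1.0-fold higher number from compound 1 to compound 4 (0.02 log units; within the scatter), and this is the first measured pair that isolates a change at this position. On this aromatic carbon, ortho to a chloro group and para to a large group, the loss of 9 heavy atoms and a six-membered aromatic ring leaves the read-out within the scatter, so this exchange alone does not separate compound 1 from compound 4. Nothing measured in this series offers a reason for this result.

As far as these compounds go, only these two groups have been compared at this position, so the effect of a primary amine or a carboxylic acid on the same carbon remains open. Also open, from the compounds shown here alone, is whether any single change elsewhere on compound 4 would shift its number beyond the scatter.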